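The source may report more compounds than this note shows. Statements on the series, on what has been measured and on what is new or still open speak of the compounds shown alone.

Measured in a functional assay on SEM cells (Homo sapiens) for cytotoxicity, with a stated time of 72 h; a higher number here means that more compound is needed for the effect, a lower number that less compound is needed:
- compound 1 `C=C[C@@](C)(/C=C/c1ccc(O)cc1)CC/C=C/C(=O)OCc1ccccc1`: > 36600 nM
- compound 2 `C=C[C@@](C)(/C=C/c1ccc(O)cc1)CC/C=C(C)/C=N/N`: > 36600 nM
- compound 3 `C=C[C@@](C)(/C=C/c1ccc(O)c(C=O)c1)CCC=C(C)C`: 8510 nM

The value of compound 1, > 36600 nM, is a limit of the assay, not a number. For compound 2, > 36600 nM is likewise a limit.

Going by the values given here, compound 3, at 8510 nM, holds the only number. The other two entries give (the limit of > 36600 nM in this assay, at which 2 of the 3 values shown sit).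

Compound 4 `C=C[C@@](C)(/C=C/c1ccc(O)c(/C=C/c2ccc(F)cc2)c1)CCC=C(C)C` carries 2-(4-fluorophenyl)ethenyl in place of the formyl of compound 3, on an aromatic carbon, ortho to a hydroxy group: 2-(4-fluorophenyl)ethenyl in place of formyl on an aromatic carbon.

Among the compounds with values here, no measured pair differs in one place only, so no direction is favoured. In this assay, the estimated change a 1.1-fold lower number from compound 3 to compound 4 (0.05 log units; within the scatter) is expected to stay within the scatter.

Compound 4 is estimated at 7500 nM, with an expected range of 2500 nM to 25000 nM.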

Compound 4, half-maximal effective concentration: > 36600 nM
Compound 4: no number, only a limit; the forecaster's own chance of this, stated with the estimate: 20%; at least 4.8-fold (0.68 log units) between middle value and limit.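

Going by these compounds alone, on an aromatic carbon ortho to a hydroxy group, 2-(4-fluorophenyl)ethenyl in place of formyl gives the first readable step in this assay, with an at least 4.3-fold higher number from compound 3 to compound 4 (0.63 log units; beyond the scatter). Compound 4 gives > 36600 nM, which is a limit of the assay and not a number. Compound 3 thus remains the only compound in the series with a number: the limit of > 36600 nM in this assay, at which 3 of the 4 values shown sit.

On these data alone, how an amine or a carboxylic acid in place of formyl at this aromatic carbon would read stays open. Also open, as far as these compounds go, is whether the fluorine of the entering group has any part in this step.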